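The source may report more compounds than this note shows. Statements on the series, on what has been measured and on what is new or still open speak of the compounds shown alone.

Measured in an ADME assay on L02 cells (Homo sapiens) for cytotoxicity, read by MTT assay, with a stated time of 24 h; on this read-out higher numbers stand for weaker inhibition and lower numbers for stronger inhibition:
Compound 1 `CN1C/C(=C\c2ccc(C#N)cc2)C(=O)/C(=C/c2cccnc2)C1`: > 20000 nM
Compound 2 `CN1C/C(=C\c2ccncc2)C(=O)/C(=C/c2ccccc2F)C1`: 14900 nM
Compound 3 `CN1C/C(=C\c2ccncc2)C(=O)/C(=C/c2ccc(C(F)(F)F)cc2)C1`: 17400 nM

Compound 1 gives > 20000 nM, which is a limit of this assay and not a number. The two true numbers sit level: compound 2 gives 14900 nM and compound 3 gives 17400 nM, and these lie within the usual scatter of each other.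

Compound 4 `CN1C/C(=C\c2ccncc2)C(=O)/C(=C/c2ccc(C#N)cc2)C1` differs from compound 3 in one place, with cyano in place of trifluoromethyl on an aromatic carbon, para to a large group: cyano in place of trifluoromethyl on an aromatic carbon.

Among the compounds with values here, no measured pair of compounds shows what this swap does in this assay, so the working expectation is no change beyond the scatter. The expected step is a 1.0-fold higher number from compound 3 to compound 4 (0.01 log units; within the scatter). Compound 1 also carries a cyano group, and its reading of > 20000 nM leaves open that compound 4 could also reach the limit of this assay.

Compound 4 is estimated at 18000 nM, with an expected range of 11000 nM to 28000 nM.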

Compound 4, half-maximal inhibitory concentration: 14000 nM
Estimate against measurement, compound 4: 1.3-fold (0.11 log units) above; the measured number falls inside the stated range.
By their numbers in this assay, from the lowest: compounds 4, 2 and 3 (each within the scatter of the next). At a limit, above all of these: compound 1.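

In this assay, within the data shown here, cyano in place of trifluoromethyl on this aromatic carbon gives a 1.2-fold lower number from compound 3 to compound 4 (0.09 log units; within the scatter), so the first pair to test this swap shows no change beyond the scatter, even though cyano brings a hydrogen-bond acceptor that trifluoromethyl lacks. A larger change, 4-cyanophenyl in place of 2-fluorophenyl, gives a 1.1-fold lower number from compound 2 to compound 4 (0.03 log units; within the scatter), which also stays within the scatter. Pyridin-4-yl in place of pyridin-3-yl gives an at least 1.4-fold lower number from compound 1 to compound 4 (0.15 log units; that floor lies within the scatter), but this is only a floor, and the reading of compound 1 is a limit and not a number: the limit of > 20000 nM in this assay, at which 1 of the 4 values shown sits.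

The compounds shown leave open whether any group on this aromatic carbon can move the number beyond the scatter. An amine or a carboxylic acid there would test this, since both differ more from cyano and trifluoromethyl than those two differ from each other.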